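A few compounds are considered here, and "the series" means these few. Any claim that something is new, unique, unknown or untested is made for them only; others in the source may bear on it.

Compound 1 `CC1(C)Cc2c(sc(NC(=O)c3ccccc3O)c2C(N)=O)C(C)(C)O1`: 4 nM
Compound 2 `CC1(C)Cc2c(sc(NC(=O)C3CNC(=O)C3)c2C(N)=O)C(C)(C)O1`: > 10000 nM

In an assay on cells for positive allosteric modulation of Cystic fibrosis transmembrane conductance regulator variant F508del (Homo sapiens), with stated times of 10 min and 7 s, in the presence of a further agent that is not named here (on this read-out higher numbers stand for an effect only at larger amounts of compound and lower numbers for an effect already at smaller amounts), compound 1 gives 4 nM, the only plain number among the two results shown. Compound 2 gives only a limit of the assay, > 10000 nM, as stated by the limit of > 10000 nM in this assay, at which 1 of the 2 values shown sits. Going by the values given here, the single measured step, an at least 2500-fold higher number from compound 1 to compound 2 (3.39 log units; beyond the scatter), shows that exchanging the group on the carbonyl carbon can wipe out the effect entirely.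

Compound 3 `CC1(C)Cc2c(sc(NC(=O)[C@@H](O)C(C)(C)C)c2C(N)=O)C(C)(C)O1` differs from compound 1 by 1-hydroxy-2,2-dimethylpropyl in place of 2-hydroxyphenyl on a carbonyl carbon. This resembles the measured step in that a ring gives way to a group without a ring on the carbonyl carbon, while the hydroxyl group is retained. The expectation for the step from compound 1 is therefore a large rise in this assay, a 150-fold higher number from compound 1 to compound 3 (2.18 log units; beyond the scatter), though possibly short of the limit. Compound 3 is estimated at 600 nM, within a range of 60 nM to 10000 nM.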

Compound 3, half-maximal effective concentration: 2.7 nM
Estimate against measurement, compound 3: 220-fold (2.35 log units) above; measured number below the stated range.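

In this assay, a group with no ring on the carbonyl carbon matches 2-hydroxyphenyl, as 1-hydroxy-2,2-dimethylpropyl leaves the result within the scatter (a 1.5-fold lower number from compound 1 to compound 3 (0.17 log units; within the scatter)). An aromatic ring is therefore not needed at this position, and a ring alone does not decide the outcome: 5-oxopyrrolidin-3-yl is a ring, yet replacing it with the open-chain group gives a large change (an at least 3700-fold lower number from compound 2 to compound 3 (3.56 log units; beyond the scatter)), and among these three compounds, the two that carry a hydroxyl group are the two with plain numbers. The value of compound 2 is a limit and not a number: the limit of > 10000 nM in this assay, at which 1 of the 3 values shown sits.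

The compounds shown leave open whether the hydroxyl group itself is required, or whether an amine or a carboxylic acid could take its place. They also leave open how the other arrangement at the stereocentre of 1-hydroxy-2,2-dimethylpropyl, or a longer chain, would behave.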